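This account rests on a few compounds, and the source may have more. Where it says the series, first, only, none or still open, it means among the compounds named here.

Three close analogues share one core and differ only in the aromatic group on the five-membered ring. Compound 1 `O=C(NO)c1ccc(NCc2nc(-c3ccc(Br)o3)nn2-c2ccccc2)cc1` gives 55.8% in an assay on Sf9 cells for inhibition of protein deacetylase HDAC6 (Homo sapiens), read by fluorescence, with a stated time of 40 min, tested at 100 nM (a higher number here means more inhibition at the concentration tested (going by the name of the read-out), a lower number less inhibition), compound 2 `O=C(NO)c1ccc(NCc2nc(-c3ccc(Br)cc3)nn2-c2ccccc2)cc1` gives 54.7%, and compound 3 `Cc1ccccc1-c1nc(CNc2ccc(C(=O)NO)cc2)n(-c2ccccc2)n1` gives 53.2%. The three numbers sit together: the steps of a number 1.1 percentage points lower from compound 1 to compound 2 (within the scatter), a number 2.6 percentage points lower from compound 1 to compound 3 (within the scatter) and a number 1.5 percentage points lower from compound 2 to compound 3 (within the scatter) are all within the scatter, so compound 3, though it carries the smallest number, cannot be called weaker than the others. Compound 4 `O=C(NO)c1ccc(NCc2nc(-c3ccccn3)nn2-c2ccccc2)cc1` changes the same position once more: pyridin-2-yl in place of 2-methylphenyl on an aromatic carbon. Going by the values given here, since every swap at this position so far left the inhibition unchanged beyond the scatter, no step beyond the scatter is expected, a number 0.2 percentage points lower from compound 3 to compound 4 (within the scatter). Compound 4 is therefore estimated at 53%, in a range from 43% to 63%.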

Compound 4, a percentage reported as inhibition, at one concentration (the size of the read-out at that concentration, not a potency): 58.6%
Estimate against measurement, compound 4: 5.6 percentage points below; low and high end bracket the measured number.
By their numbers in this assay, from the lowest: compounds 3, 2, 1 and 4 (each within the scatter of the next).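

Going by these compounds alone, compound 4 puts a ring nitrogen at this position for the first time, and in this assay all three steps to it stay within the scatter (a number 5.4 percentage points higher from compound 3 to compound 4 (within the scatter); a number 3.9 percentage points higher from compound 2 to compound 4 (within the scatter); a number 2.8 percentage points higher from compound 1 to compound 4 (within the scatter)). A six-membered aromatic ring with a hetero atom therefore reads the same here as the rings tested before it. Nothing measured here speaks to the reason for this. As far as these compounds go, all four groups are aromatic rings, so it stays open whether an amine, a carboxylic acid or a longer chain at this position would read the same.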